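This account rests on a few compounds, and the source may have more. Where it says the series, first, only, none or still open, it means among the compounds named here.

Measured compounds in a functional assay on Ehrlich cells (Mus musculus) for cytotoxicity, tested at 50 ug/mL; a lower number here means a weaker effect, a higher number a stronger effect of the compound at the concentration tested:
compound 1 `COc1cc(N2C(N)=C(C#N)C(c3ccc([N+](=O)[O-])cc3)C3=C2CC(C)(C)CC3=O)cc(OC)c1OC` gives 70%;
compound 2 `COc1cc(N2C(N)=C(C#N)C(c3ccc(O)cc3)C3=C2CC(C)(C)CC3=O)cc(OC)c1OC` gives 90%;
compound 3 `COc1cc(N2C(N)=C(C#N)C(c3c(OC)ccc4ccccc34)C3=C2CC(C)(C)CC3=O)cc(OC)c1OC` gives 10%.

Compound 2 stands highest of the three in this assay, with compound 1 nearest and compound 3 furthest away, both steps beyond the scatter. Compound 4 `COc1cc(N2C(N)=C(C#N)C(c3ccc(C)o3)C3=C2CC(C)(C)CC3=O)cc(OC)c1OC` differs from compound 2 in one place: 5-methylfuran-2-yl in place of 4-hydroxyphenyl on a saturated ring carbon. Going by the values given here, two measured steps bear on this change. Exchanging the group on the saturated ring carbon gave a number 80 percentage points lower from compound 2 to compound 3 (beyond the scatter), and hydroxy in place of nitro on an aromatic carbon gave a number 20 percentage points higher from compound 1 to compound 2 (beyond the scatter). Neither step brings in a five-membered aromatic ring with 1 hetero atom, so the data speak only loosely to compound 4. A downward step beyond the scatter is expected, a number 30 percentage points lower from compound 2 to compound 4 (beyond the scatter). Compound 4 is therefore estimated at 60%, with a range from 25% to 90%.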

Compound 4, a percentage reported as activity, at one concentration (the size of the read-out at that concentration, not a potency): 41%
Beside the measured number, compound 4's estimate is 19 percentage points above it, and the stated range covers the measured number.
By their numbers in this assay, from the lowest: compound 3; then compound 4; then compound 1; then compound 2.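

In this assay the exchange to 5-methylfuran-2-yl on the saturated ring carbon gave a number 49 percentage points lower from compound 2 to compound 4 (beyond the scatter) and a number 29 percentage points lower from compound 1 to compound 4 (beyond the scatter) but also a number 31 percentage points higher from compound 3 to compound 4 (beyond the scatter) in the same position. A five-membered aromatic ring with 1 hetero atom therefore sits between 2-methoxynaphthalen-1-yl and the two substituted phenyl groups here. Nothing measured on these compounds explains that order. Still open, on these data alone, is what the methyl group on the furan contributes, and how an unsubstituted furan, a thiophene or a pyridine would read at this position.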